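This account rests on a few compounds, and the source may have more. Where it says the series, first, only, none or still open, it means among the compounds named here.

Values so far in a functional assay on DU-145 cells (Homo sapiens) for inhibition, read by trypan blue exclusion, with a stated time of 96 h; on this read-out lower numbers stand for stronger inhibition of growth and higher numbers for weaker inhibition of growth
- compound 1 `Cc1ccc(S(=O)(=O)/C(=C/c2ccc(C)s2)C(=O)c2ccc(Br)cc2)cc1` gives 25000 nM
- compound 2 `Cc1ccc(S(=O)(=O)/C(=C/c2ccc(C)s2)C(=O)c2ccc(Cl)cc2)cc1` gives 50000 nM
- compound 3 `Cc1ccc(/C=C(\C(=O)c2ccc(Br)cc2)S(=O)(=O)Cc2ccc(F)cc2)s1` gives 1000 nM

Compound 1 stands at the high end of these three numbers, level with its nearest neighbour, as the halogen swap gives a 2.0-fold higher number from compound 1 to compound 2 (0.30 log units; within the scatter). The one clear move in the series is the change on the sulfonyl sulfur, which gives a 25-fold lower number from compound 1 to compound 3 (1.40 log units; beyond the scatter).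

Compound 4 `Cc1ccc(S(=O)(=O)/C(=C/c2c(O)cc(O)cc2O)C(=O)c2ccc(Br)cc2)cc1` keeps the rest of compound 1 and differs at one place: 2,4,6-trihydroxyphenyl in place of 5-methylthiophen-2-yl on a double-bonded chain carbon bound to a double-bonded chain carbon. Neither measured step touches this place, and the series holds no direct measurement of a change there. Within the data shown here, the larger step, a 25-fold lower number from compound 1 to compound 3 (1.40 log units; beyond the scatter), shows only that a single change can move the number well beyond the scatter, so it argues for a wide range rather than a firm size. A moderate shift to a lower number in this assay is expected, though a result within the scatter remains possible. The expected step is a 2.1-fold lower number from compound 1 to compound 4 (0.32 log units; beyond the scatter). For compound 4 the estimated value is 12000 nM, with an expected range from 2500 nM to 50000 nM.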

Compound 4, concentration for 50% growth inhibition: > 100000 nM
Compound 4: only a limit was reported; the forecaster's own chance of this, stated with the estimate: 10%; middle value at least 8.3-fold (0.92 log units) from the limit.
By their numbers in this assay, from the lowest: compound 3; then compounds 1 and 2 (each within the scatter of the next). At a limit, above all of these: compound 4.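

In this assay, the place on a double-bonded chain carbon bound to a double-bonded chain carbon now has a measured change: 2,4,6-trihydroxyphenyl in place of 5-methylthiophen-2-yl gives an at least 4.0-fold higher number from compound 1 to compound 4 (0.60 log units; beyond the scatter). The reading for compound 4 is a limit, not a number: the limit of > 100000 nM in this assay, at which 1 of the 4 values shown sits.

Among these compounds, the only earlier step beyond the scatter was at the sulfonyl sulfur and ran to a lower number, so this place is the first to show a step beyond the scatter to a higher number.

From the compounds shown here alone, whether the change of ring or the hydroxyl groups account for this step stays open, as does how a plain phenyl or a methoxyphenyl would read at this place. Also open, going by these compounds, is how 2,4,6-trihydroxyphenyl would read alongside the 4-fluorobenzyl group of compound 3.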